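This account rests on a few compounds, and the source may have more. Where it says the series, first, only, none or still open, it means among the compounds named here.

Working notes on the series. In an ADME assay on L6 cells (Rattus norvegicus) for cytotoxicity (on this read-out higher numbers stand for weaker inhibition and lower numbers for stronger inhibition), compound 1 (`N#Cc1ccccc1N1CCN(C(=O)Cn2cnc([N+](=O)[O-])n2)CC1`) gives 213000 nM, compound 2 (`Cc1ccc(N2CCN(C(=O)Cn3cnc([N+](=O)[O-])n3)CC2)cc1`) gives 148000 nM and compound 3 (`O=C(Cn1cnc([N+](=O)[O-])n1)N1CCN(c2ncccn2)CC1`) gives 150000 nM. Compound 2 stands within the scatter of both other compounds, and the three values do not separate. The measured steps are a 1.4-fold lower number from compound 1 to compound 2 (0.16 log units; within the scatter), a 1.4-fold lower number from compound 1 to compound 3 (0.15 log units; within the scatter) and a 1.0-fold higher number from compound 2 to compound 3 (0.01 log units; within the scatter).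

The next compound is compound 4 (`O=C(Cn1cnc([N+](=O)[O-])n1)N1CCN(c2ccc(C(F)(F)F)cc2)CC1`). It carries trifluoromethyl in place of methyl on an aromatic carbon, para to a large group: trifluoromethyl in place of methyl on an aromatic carbon. For the measured compounds named here, no measured step changes this substituent alone, so the evidence is indirect. The three steps above each exchange the whole group on the amine nitrogen in a ring, which is a larger edit than the one at hand. Even so, none of them leaves the scatter, and the closest case is a 1.0-fold higher number from compound 2 to compound 3 (0.01 log units; within the scatter), which starts from compound 2 itself. On that basis no step beyond the scatter is expected in this assay, and no direction can be argued from these data. The expected step is a 1.1-fold lower number from compound 2 to compound 4 (0.06 log units; within the scatter). For compound 4 the estimated value is 130000 nM, with an expected range of 65000 nM to 230000 nM.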

Compound 4, half-maximal inhibitory concentration: 202000 nM
Beside the measured number, compound 4's estimate is 1.6-fold (0.19 log units) below it; measured number inside the range.
By their numbers in this assay, from the lowest: compounds 2, 3, 4 and 1 (each within the scatter of the next).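

In this assay, for the compounds shown here, the exchange on an aromatic carbon, para to a large group, gives a 1.4-fold higher number from compound 2 to compound 4 (0.14 log units; within the scatter) and is the first reading of a change confined to this substituent. Trifluoromethyl, with four heavy atoms, in place of methyl, with one, therefore leaves the number inside the scatter, so at this position the added heavy atoms produce no step that can be separated from repeat variation; the earlier exchanges of the whole group on the amine nitrogen could bear on this substituent only indirectly. No measurement of any property of these compounds accompanies the result, and the step carries no explanation.

Open, going by these compounds, is whether a different group on this aromatic carbon, such as an amine, a carboxylic acid or a longer chain, would move the number beyond the scatter in this assay where trifluoromethyl does not. Also open is whether replacing the nitro group of the shared core with an amine would change the read-out; every compound shown keeps the nitro group.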